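The source may report more compounds than this note shows. Statements on the series, on what has been measured and on what is new or still open speak of the compounds shown alone.

Compound 1: `CCc1cccc(NC(=O)CSc2nc(Nc3ccccc3)c3ccccc3n2)c1` — 15800 nM
Compound 2: `C=CC(=O)Nc1cccc(NC(=O)CSc2nc(Nc3ccccc3Cl)c3ccccc3n2)c1` — 20700 nM

In a functional assay on MGC-803 cells (Homo sapiens) for inhibition, read by MTT assay, with a stated time of 72 h (on this read-out lower numbers stand for stronger inhibition and higher numbers for weaker inhibition), compound 1 gives 15800 nM. In this assay compound 2 gives 20700 nM. These two numbers lie within the usual scatter of each other, so neither compound can be called more or less active than the other; compound 2 simply stands alongside compound 1 on the numbers shown.

Compound 3, `C=CC(=O)Nc1cccc(NC(=O)CSc2nc(Nc3ccc(Cl)cc3)c3ccccc3n2)c1`, has not yet been measured. It differs from compound 2 in one place: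
4-chlorophenyl in place of 2-chlorophenyl on a nitrogen on an aromatic ring

Among the compounds with values here, no step between two measured compounds is available here, so there is no measured guide for what a change of this kind does. With both measured compounds giving similar numbers, the step from compound 2 to compound 3 is expected to be small, and is estimated at a 1.2-fold lower number from compound 2 to compound 3 (0.06 log units; within the scatter), not beyond the scatter in either direction. Compound 3 is therefore expected to give about 18000 nM in this assay, with a likely range from 7000 nM to 45000 nM.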

Compound 3, half-maximal inhibitory concentration: 14300 nM
Estimate against measurement, compound 3: 1.3-fold (0.10 log units) above; measured number inside the range.
By their numbers in this assay, from the lowest: compounds 3, 1 and 2 (each within the scatter of the next).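

Within the data shown here, this is the first measured step at this place: in this assay, 4-chlorophenyl in place of 2-chlorophenyl on the nitrogen gives a 1.4-fold lower number from compound 2 to compound 3 (0.16 log units; within the scatter), so the two groups cannot be told apart on this read-out. For this pair, then, where the chlorine sits on the phenyl ring makes no difference that stands clear of the ordinary variation between repeated measurements. Nothing available on these compounds speaks to why the two read alike.

On these data alone, what remains open is whether this nitrogen tolerates other groups equally well, since both compounds compared here carry a chlorophenyl group of the same size. A carboxylic acid or an amine on that phenyl ring in place of the chlorine, or a simple alkyl chain in place of the whole ring, could show whether this position can shift the number beyond the scatter at all.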